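Methoxy for fluoro on the aryl of compound 1

The source may report more compounds than this note shows. Statements on the series, on what has been measured and on what is new or still open speak of the compounds shown alone.

Measured compounds:
compound 1, `Cc1oc(-c2c(F)cccc2F)nc1CN1CCC(C(=O)NCCCN2C[C@H](C)C[C@H](C)C2)CC1`: > 72 ug/mL
compound 2, `Cc1cccc(Cl)c1-c1nc(CN2CCC(C(=O)NCCCN3CCC(C)(C)CC3)CC2)c(C)o1`: > 74 ug/mL

In a physicochemical assay for solubility, in phosphate buffer, measured as kinetic solubility, at pH 7.4 (a higher number here means a more soluble compound, a lower number a less soluble compound), compound 1 gives > 72 ug/mL, which is a limit of the assay and not a number (the limit of > 72 ug/mL in this assay, at which 1 of the 2 values shown sits). Compound 2 gives > 74 ug/mL, likewise a limit (the limit of > 74 ug/mL in this assay, at which 1 of the 2 values shown sits). Going by the values given here, both values shown are limits, so no step between measured compounds can be stated, and compound 1 simply sits at its limit. Compound 3 is `COc1cccc(F)c1-c1nc(CN2CCC(C(=O)NCCCN3C[C@H](C)C[C@H](C)C3)CC2)c(C)o1`; it differs from compound 1 by methoxy in place of fluoro on an aromatic carbon. In this assay the step is expected to stay within the scatter, with no direction: a step that the limit leaves unreadable from compound 1 to compound 3. Compound 3 is expected at 75 ug/mL, between 40 ug/mL and 150 ug/mL, most likely reported again only as a limit.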

Compound 3, solubility: > 74 ug/mL
Compound 3: only a limit was reported; the forecaster's own chance of this, stated with the estimate: 70%; the middle value is on the limit's open side.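

In this assay, going by these compounds alone, compound 1 and compound 3 are both reported only as limits, so no step between them can be read. The compounds shown leave open where the true values lie, and whether methoxy in place of fluoro shifts them at all.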